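Swapping the Amide Arm for an Octyl Chain

The source may report more compounds than this note shows. Statements on the series, on what has been measured and on what is new or still open speak of the compounds shown alone.

compound 1, `CCOC(=O)C1=Cc2ccccc2OC1(OCc1cn(CC(=O)Nc2ccccc2Br)nn1)C(F)(F)F`: > 150000 nM
compound 2, `CCOC(=O)C1=Cc2ccccc2OC1(OCc1cn(CC(=O)Nc2ccccc2F)nn1)C(F)(F)F`: 50100 nM

In a functional assay on A549 cells (Homo sapiens) for inhibition, read by MTT assay, with a stated time of 24 h (on this read-out lower numbers stand for stronger inhibition and higher numbers for weaker inhibition), compound 2 gives 50100 nM, the one number shown. For compound 1 this assay reports a limit, > 150000 nM. The step of an at least 2.9-fold lower number from compound 1 to compound 2 (0.47 log units; beyond the scatter) is the only measured one, and it concerns the aromatic ring that compound 3 `CCCCCCCCn1cc(COC2(C(F)(F)F)Oc3ccccc3C=C2C(=O)OCC)nn1` no longer carries: heptyl in place of (2-fluorophenyl)carbamoyl on a saturated chain carbon bound to an aromatic nitrogen. Among the compounds with values here, no measured step bears on this change, so no direction can be drawn from it. Compound 3 is expected to give about 45000 nM, between 8000 nM and 200000 nM. That estimate means an expected step of a 1.1-fold lower number from compound 2 to compound 3 (0.05 log units; within the scatter), within the usual scatter.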

Compound 3, half-maximal inhibitory concentration: > 150000 nM
Compound 3: only a limit was reported (the forecaster's own chance of this, stated with the estimate: 30%); middle value at least 3.3-fold (0.52 log units) from the limit.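

At this position, the saturated chain carbon bound to an aromatic nitrogen, the octyl chain does not hold the level of the ((2-fluorophenyl)carbamoyl)methyl arm: this assay shows an at least 2.9-fold higher number from compound 2 to compound 3 (0.47 log units; beyond the scatter) for this exchange. Within the data shown here, the one number in the set thus belongs to a compound carrying the amide arm. Compound 1 and compound 3 both give limits, the step between them cannot be read, and the set gathers at one limit: the limit of > 150000 nM in this assay, at which 2 of the 3 values shown sit.

Going by these compounds, it stays open whether the amide or the aromatic ring carries the difference. Equally open, on these data alone, is whether a shorter chain, a chain ending in an amine or a carboxylic acid, or a benzyl group here would bring the number back down.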